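The compounds below may be only part of what the source reports. "The series", "measured", "known", "first", "only" and "open" are said of these compounds alone.

Measured so far in an ADME assay on microsomes from liver (Mus musculus) for metabolic stability, with a stated time of 1 h; a lower number here means that less of the compound is left, a higher number that more of the compound is left:
Compound 1 `COc1ccc(Nc2ccc3c(C4CCN(C)CC4)c[nH]c3c2)cc1OC`: 70%
Compound 2 `c1cc2c(C3CCNCC3)c[nH]c2cc1Nc1ccc2c(C3CCNCC3)c[nH]c2c1`: "not determined" (no result reported)
Compound 3 `Fc1ccc(Nc2ccc3c(C4CCNCC4)c[nH]c3c2)cc1F`: 85%

Only two of these compounds have a number. Compound 3 holds the higher one at 85%, and the gap down to compound 1 at 70% lies beyond the usual scatter of repeat measurements.

The next compound to be tested is compound 4 `Cn1cc(C2CCNCC2)c2ccc(Nc3ccc(F)c(F)c3)cc21`. It is compound 3 with one small edit: methyl in place of hydrogen on an aromatic nitrogen. In words, this is methyl in place of hydrogen on an aromatic nitrogen.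

Among the compounds with values here, no pair of measured compounds shows this edit, so any forecast here is tentative. Compound 3 already gives 85%, which leaves little room for a rise in the share remaining. A small downward step is therefore expected, a number 8 percentage points lower from compound 3 to compound 4 (within the scatter), which would stay within the usual scatter.

For compound 4 the estimated value in this assay is 77%, with an expected range from 58% to 92%.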

Compound 4, percent of the compound remaining: 83%
For compound 4 the middle estimate is 6 percentage points below the measured one, and the stated range covers the measured number.
By their numbers in this assay, from the lowest: compound 1; then compounds 4 and 3 (each within the scatter of the next).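

In this assay, methyl in place of hydrogen on the aromatic nitrogen gives a number 2 percentage points lower from compound 3 to compound 4 (within the scatter). Within the data shown here, this is the first step seen at this position, two ring bonds from the ring atom that bears the piperidin-4-yl group, and it shows that, in this pair, the hydrogen on the nitrogen is not needed to keep a high share of compound remaining. Nothing measured here explains why the step is so small.

Methyl is the only group seen on this nitrogen, so it remains open whether a larger group, such as a longer chain, an acetyl group or a chain ending in an amine, would leave the share remaining just as high. Going by these compounds, it is also open whether the same edit would give a similar step on compound 1.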